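Methoxy in Place of Methyl on the Acid Carbon

The compounds below may be only part of what the source reports. "The series", "measured", "known", "first", "only" and "open" are said of these compounds alone.

Measured compounds:
compound 1, `CC(C(=O)O)c1nn(Cc2cn3cc(OCC4CC4)c(Cl)cc3n2)c2ccccc2c1=O`: 1.3 nM
compound 2, `C[C@@H](C(=O)O)c1nn(Cc2cn3cc(OCC4CC4)c(Cl)cc3n2)c2ccccc2c1=O`: 182 nM
compound 3, `O=C(O)Cn1nc(Cc2cn3cc(OCC4CC4)c(Cl)cc3n2)c2ccccc2c1=O`: 7.6 nM

In a functional assay on HFL1 cells for antagonist activity at sphingosine 1-phosphate receptor 2 (Homo sapiens), read by ELISA, with a stated time of 24 h (a higher number here means a weaker inhibitor, a lower number a stronger inhibitor), compound 2 stands highest of the three numbers; compound 3 gives 7.6 nM and compound 1 gives 1.3 nM, both beyond the scatter from it. Compound 4, `COC(C(=O)O)c1nn(Cc2cn3cc(OCC4CC4)c(Cl)cc3n2)c2ccccc2c1=O`, differs from compound 2 by carboxy(methoxy)methyl in place of 1-carboxyethyl on an aromatic carbon; the new group carries no drawn configuration. For the measured compounds named here, the one measured step that bears on this is a 140-fold higher number from compound 1 to compound 2 (2.15 log units; beyond the scatter), the sole change there being (the fact that one of compounds 1 and 2 is drawn with a defined configuration and the other without, at the place where they differ). Compound 4, drawn like compound 1 without configuration, is therefore expected to give a much lower number, a 36-fold lower number from compound 2 to compound 4 (1.56 log units; beyond the scatter). Compound 4 is estimated at 5 nM, with a range from 1 nM to 40 nM.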

Compound 4, half-maximal inhibitory concentration: 94 nM
Compound 4: the middle estimate sits 19-fold (1.27 log units) below what was measured; measured number outside the range, above it.
By their numbers in this assay, from the lowest: compound 1; then compound 3; then compounds 4 and 2 (each within the scatter of the next).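

Swapping methyl for methoxy on this saturated chain carbon, with no configuration drawn in either compound, gives a 72-fold higher number from compound 1 to compound 4 (1.86 log units; beyond the scatter), so the choice of group here matters as well. For the compounds shown here, until now the only change at this carbon was this: the fact that one of compounds 1 and 2 is drawn with a defined configuration and the other without, at the place where they differ. Set against the drawn form, the new group gives a 1.9-fold lower number from compound 2 to compound 4 (0.29 log units; within the scatter), so those two compounds cannot be told apart in this assay.

Still open, on these data alone, is how a hydroxy or ethyl group on this carbon would read. Also open, as far as these compounds go, is whether a drawn configuration in compound 4 would shift its number.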